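The source may hold more compounds than are shown below. What is called first, only, known or untested is meant among the compounds shown, and "the series" means these compounds.

Of the compounds shown here, two from this series have been tested so far. Compound 1 (`COC(=O)[C@@]1(C)CCC=C2[C@@H]1CC[C@@H](C)[C@]2(C)Cc1c(C)[nH]c2ccc(C(F)(F)F)cc12`) gives 12000 nM in a functional assay on HeLa cells (Homo sapiens) for inhibition, read by sulforhodamine B assay, with a stated time of 48 h; on this read-out higher numbers stand for weaker inhibition of growth and lower numbers for stronger inhibition of growth. Compound 2 (`COC(=O)[C@@]1(C)CC[C@@H]2C3=C1CC[C@@H](C)[C@]3(C)C[C@@H]1c3ccccc3N[C@H]21`) gives 19000 nM in this assay. These two numbers lie within the usual scatter of repeated measurements, so compound 2 stands alongside compound 1 and neither can be called the weaker or the stronger of the pair.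

The next step leads to compound 3 (`COC(=O)[C@@]1(C)CC[C@@H]2C3=C1CC[C@@H](C)[C@]3(C)C[C@@H]1c3cc(C)ccc3N[C@H]21`), which has not yet been measured. It differs from compound 2 in one place only: methyl in place of hydrogen on an aromatic carbon. The shared core, including the ester and the two fused ring systems, is otherwise unchanged.

Going by the values given here, no comparable single change has been measured within this set, so there is no step to lean on. A single methyl added to an aromatic ring is a small alteration, and for a pair of compounds that already sit in the same range, the expected step from compound 2 to compound 3 in this assay is a 1.3-fold lower number from compound 2 to compound 3 (0.10 log units; within the scatter), which is nothing beyond the scatter. Compound 3 is therefore estimated at 15000 nM, with a likely range from 6000 nM to 40000 nM.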

Compound 3, concentration for 50% growth inhibition: 18000 nM
Estimate against measurement, compound 3: 1.2-fold (0.08 log units) below, within the range that was stated.
By their numbers in this assay, from the lowest: compounds 1, 3 and 2 (each within the scatter of the next).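

Going by these compounds alone, this is the first single change that can be read in this set. In this assay, placing methyl in place of hydrogen on this aromatic carbon gives a 1.1-fold lower number from compound 2 to compound 3 (0.02 log units; within the scatter), so compound 2 and compound 3 stand alongside each other and this added carbon, meta to a fused ring and para to a fused ring, brings no measurable difference in growth inhibition. Nothing measured here offers an explanation for this result.

As far as these compounds go, a single small group at a single position says little about the wider scope of this carbon, so it remains open whether a longer chain, a methoxy group, a chlorine atom or an amine at the same place would stay within the scatter or shift the number clearly in either direction. From the compounds shown here alone, it is also open whether methyl on the other carbons of this aromatic ring would behave as it does here, and a reading at those places would show whether this result is particular to this position or holds across the ring.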